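2-phenylethenyl in place of 5-bromo-2-hydroxyphenyl: expected step

The source may hold more compounds than are shown below. What is called first, only, known or untested is meant among the compounds shown, and "the series" means these compounds.

Values so far in a functional assay on MCF7 cells (Homo sapiens) for cytotoxicity, read by MTT assay, with a stated time of 48 h (on this read-out higher numbers stand for weaker inhibition and lower numbers for stronger inhibition), for each compound:
compound 1 `O=C(CSc1nnc(-c2ccncc2)o1)N/N=C/c1ccc(Cl)cc1` (15300 nM)
compound 2 `O=C(CSc1nnc(-c2ccncc2)o1)N/N=C/c1cccc(F)c1` (24900 nM)
compound 3 `O=C(CSc1nnc(-c2ccncc2)o1)N/N=C/c1cc(Br)ccc1O` (7770 nM)

Compound 3 stands close to one neighbour and apart from the other. The steps into it are a 2.0-fold lower number from compound 1 to compound 3 (0.29 log units; within the scatter) and a 3.2-fold lower number from compound 2 to compound 3 (0.51 log units; beyond the scatter) so only compound 2 lies clearly away from it.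

Within the data shown here, compound 4 `O=C(CSc1nnc(-c2ccncc2)o1)N/N=C/C=C/c1ccccc1` has no measurement yet. Its change from compound 3 is 2-phenylethenyl in place of 5-bromo-2-hydroxyphenyl on a carbon with a double bond to nitrogen with 2-phenylethenyl in place of 5-bromo-2-hydroxyphenyl on a carbon with a double bond to nitrogen. Among the measured compounds shown here, no measured compound carries 2-phenylethenyl, so the evidence is indirect.

All three measured steps sit at this same place. The third, a 1.6-fold higher number from compound 1 to compound 2 (0.21 log units; within the scatter) adds little. Going by a 3.2-fold lower number from compound 2 to compound 3 (0.51 log units; beyond the scatter) as the largest of them, nothing larger is assumed here.

In this assay the expected step is a 1.8-fold higher number from compound 3 to compound 4 (0.26 log units; within the scatter) as a modest move towards higher numbers.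

Compound 4 is expected at 14000 nM (estimated range 5000 nM to 40000 nM).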

Compound 4, half-maximal inhibitory concentration: 10800 nM
Compound 4: the middle estimate sits 1.3-fold (0.11 log units) above what was measured; measured number inside the range.
By their numbers in this assay, from the lowest: compounds 3, 4, 1 and 2 (each within the scatter of the next, the first and the last beyond it).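

In this assay, 2-phenylethenyl on the carbon with a double bond to nitrogen gives a 1.4-fold higher number from compound 3 to compound 4 (0.14 log units; within the scatter) and a 1.4-fold lower number from compound 1 to compound 4 (0.15 log units; within the scatter) within the scatter in both cases, and only a 2.3-fold lower number from compound 2 to compound 4 (0.36 log units; beyond the scatter) lies beyond it. Among these compounds, then, the bromine and hydroxyl of 5-bromo-2-hydroxyphenyl are not needed for a number level with compound 3: a carbon-only group with no hydrogen-bond donors or acceptors and a double bond outside aromatic rings does as well here, with compound 2 the one compound standing apart. No measurement on these compounds points to a cause for this.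

Open, going by these compounds, is whether a group with no aromatic ring, such as a longer alkyl chain, or one carrying an amine or a carboxylic acid, holds the number at this level at this place. On these data alone, all four compounds share the rest of the core, so what changes there does to these numbers also stays open.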